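The compounds below may be only part of what the source reports. "The series", "measured", "known", "first", "only" and "open" are said of these compounds alone.

In an ADME assay on microsomes from liver (Homo sapiens) for metabolic stability, read by LC-MS, using NADPH, with a stated time of 30 min, tested at 0.1 uM, in the presence of a further agent that is not named here (on this read-out higher numbers stand for a more stable compound and lower numbers for a less stable compound), compound 2 `Nc1ncc(-c2ccc(C(=O)O)cc2)nc1-c1ccc(C(F)(F)F)cc1` gives > 90%, which is a limit of the assay and not a number. Compound 3 `Nc1ncc(-c2ccc(C(=O)N3CCC(O)CC3)cc2)nc1-c1ccc(C(F)(F)F)cc1` differs from it in one place: 4-hydroxypiperidin-1-yl in place of hydroxy on a carbonyl carbon. Compound 1 `Nc1ncc(-c2ccc(C(=O)N3CC(O)C3)cc2)nc1-c1ccc(C(F)(F)F)cc1`, which holds 3-hydroxyazetidin-1-yl on that carbonyl carbon, gives > 90%, also a limit. Among the compounds with values here, the one measured step at this place is a step that the two limits leave unreadable from compound 1 to compound 2. Both of its ends are limits, so it offers no size to carry over. Within the data shown here, the only guide is the limit of > 90% in this assay, at which 2 of the 2 values shown sit. On that basis, no step beyond the usual scatter is expected in this assay, and no direction can be named. The expected size is a number no higher from compound 2 to compound 3 (the limit leaves the size open). Compound 3 is expected at 90%, with an estimated range from 75% to 98%.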

Compound 3, percent of the compound remaining: > 90%
Compound 3 gave a limit, no number; the forecaster's own chance of this, stated with the estimate: 55%; the middle value sits exactly at the limit.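

In this assay compound 3 gives > 90%, a limit of the assay and not a number. Within the data shown here, compound 1 and compound 2 also sit at a limit, so no step among the three compounds can be read: the limit of > 90% in this assay, at which 3 of the 3 values shown sit. On these data alone, whether hydroxy, 3-hydroxyazetidin-1-yl and 4-hydroxypiperidin-1-yl on the carbonyl carbon differ in stability, and by how much, stays open.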